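A few compounds are considered here, and "the series" means these few. Any claim that something is new, unique, unknown or untested is made for them only; others in the source may bear on it.

Compound 1 `COc1ccc(C2=NNC(c3c(Cl)cccc3Cl)C2)cc1OC` is the starting point of this step. In a functional assay on the whole organism (strain albino) for inhibition, with Rattus norvegicus as the target, read by paw edema, with stated times of 30 min and 3 h, at a dose of 100 mg/kg by the oral route (a higher number here means more inhibition at the dose given (going by the name of the read-out), a lower number less inhibition), compound 1 gives 58%, which is the lowest of the two numbers recorded so far. The nearest neighbour is compound 2 `COc1ccc(C2=NNC(c3c(Cl)cccc3Cl)C2)cc1`, which in this assay gives 60%; the step of a number 2 percentage points higher from compound 1 to compound 2 (within the scatter) comes from hydrogen in place of methoxy on an aromatic carbon and stays within the scatter.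

The compound awaiting measurement is compound 3 `COc1ccc(C2=NN(C(=O)C(C)Br)C(c3c(Cl)cccc3Cl)C2)cc1OC`. It differs from compound 1 by (1-bromoethyl)carbonyl in place of hydrogen on an amine nitrogen in a ring. Going by the values given here, the change places a (1-bromoethyl)carbonyl group on an amine nitrogen in a ring, far from the aromatic carbon at which the single measured step was taken. That step, a number 2 percentage points higher from compound 1 to compound 2 (within the scatter), was within the scatter and does not speak to an acyl group on the ring nitrogen. Among the compounds with values here, no measured step therefore bears on this change, and no shift beyond the scatter is expected in either direction.

On that basis compound 3 is estimated to give 60% in this assay, with a range from 40% to 78%. The expected step is a number 2 percentage points higher from compound 1 to compound 3 (within the scatter).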

Compound 3, a percentage reported as inhibition, in the whole organism at one dose (the size of the read-out at that dose, not a potency): 60%
Estimate against measurement, compound 3: no gap at the digits printed; the range from low to high includes it.
By their numbers in this assay, from the lowest: compounds 1, 2 and 3 (each within the scatter of the next).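

Going by these compounds alone, the ring nitrogen had not been varied among the earlier compounds, whose only step lay on an aromatic carbon. In this assay, (1-bromoethyl)carbonyl in place of hydrogen on this amine nitrogen in a ring gives a number 2 percentage points higher from compound 1 to compound 3 (within the scatter), so at the dose given, the read-out does not depend on that nitrogen keeping its hydrogen, and the core of compound 1 carries this added group with no shift beyond the scatter. No measurement available here explains why the read-out holds with this group in place.

From the compounds shown here alone, it remains open whether the same holds for other groups on this nitrogen, such as an acetyl group without the bromine, a longer chain, or a carbonyl chain ending in an amine, and whether the bromine contributes anything to the read-out. Also open, going by these compounds, is whether the same change on compound 2 would give the same result, and whether compound 1 and compound 3 would still match at other doses, since a reading at a single dose shows the size of the inhibition and not a potency.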